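A few compounds are considered here, and "the series" means these few. Any claim that something is new, unique, unknown or untested is made for them only; others in the source may bear on it.

In a functional assay on A549 cells (Homo sapiens) for inhibition, read by MTT assay, with a stated time of 72 h (on this read-out lower numbers stand for stronger inhibition and higher numbers for weaker inhibition), the three measured compounds gave the following results:

compound 1 `CN(C(=O)NC(=O)c1ccc(F)c(F)c1)c1nc(C(F)(F)F)c(C(=O)N/N=C/c2ccccc2C(F)(F)F)s1`: 6.96 ug/mL
compound 2 `Cc1nc(N(C)C(=O)NC(=O)c2c(F)cccc2F)sc1C(=O)N/N=C/c1cccc(C(F)(F)F)c1`: 30.3 ug/mL
compound 3 `CN(C(=O)NC(=O)c1ccc(F)c(F)c1)c1nc(C(F)(F)F)c(C(=O)N/N=C/c2cccc(C(F)(F)F)c2)s1`: 6.52 ug/mL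

Compound 3 and compound 1 share one core and differ only by 2-(trifluoromethyl)phenyl in place of 3-(trifluoromethyl)phenyl on a carbon with a double bond to nitrogen. In this assay this change made a 1.1-fold higher number from compound 3 to compound 1 (0.03 log units; within the scatter), so the two compounds cannot be told apart on this read-out. Compound 2 is built on a different core, and how the two cores differ is not broken down here; its value is the highest of the three, and its gaps to compound 1 and to compound 3 are both beyond the scatter.

Compound 4 `Cc1nc(N(C)C(=O)NC(=O)c2c(F)cccc2F)sc1C(=O)N/N=C/c1ccccc1C(F)(F)F` has not yet been measured. Within the data shown here, it differs from compound 2 by 2-(trifluoromethyl)phenyl in place of 3-(trifluoromethyl)phenyl on a carbon with a double bond to nitrogen, which is the same change as the one from compound 3 to compound 1, made at the same place. Because the earlier step was a 1.1-fold higher number from compound 3 to compound 1 (0.03 log units; within the scatter), the step from compound 2 to compound 4 is expected to be about as small, namely a 1.1-fold higher number from compound 2 to compound 4 (0.02 log units; within the scatter). Compound 4 is therefore estimated at 32 ug/mL in this assay, with a likely range from 15 ug/mL to 65 ug/mL.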

Compound 4, half-maximal inhibitory concentration: 5.43 ug/mL
Beside the measured number, compound 4's estimate is 5.9-fold (0.77 log units) above it, outside the stated range (below it).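

In this assay, replacing 3-(trifluoromethyl)phenyl with 2-(trifluoromethyl)phenyl gave a 5.6-fold lower number from compound 2 to compound 4 (0.75 log units; beyond the scatter), so on this core the swap makes a clear difference. Set beside the earlier case, the same swap does not carry over from one core to the other at the same size: the same change on two cores in this assay, a 1.1-fold higher number (0.03 log units; within the scatter) from compound 3 to compound 1 and a 5.6-fold lower number (0.75 log units; beyond the scatter) from compound 2 to compound 4, 6.0-fold (0.78 log units) apart, beyond the scatter of two such steps This shows that, in these two pairs, the outcome of the swap depends on the core that carries it, so a step seen on one core is a poor guide to the step on the other; it does not show which part of the two cores is responsible, or how the swap would behave on a third core.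

In the compounds shown, the phenyl ring at this place carries only a trifluoromethyl group, so it remains open how a chlorine, a methoxy group or a nitrile would behave there on either core. Also open, from the compounds shown here alone, is whether a core carrying only part of the difference between these two cores would follow the pair of compound 3 and compound 1 or that of compound 2 and compound 4.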